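Para-substituent variation on the aryl at the amide-bearing nitrogen

A few compounds are considered here, and "the series" means these few. Any claim that something is new, unique, unknown or untested is made for them only; others in the source may bear on it.

Measured compounds:
compound 1 `CC1C(=O)CC(c2ccc(F)cc2)N(C(=O)CCl)C1c1ccc(O)cc1`, 51.2%
compound 2 `CC1C(=O)CC(c2ccc(F)cc2)N(C(=O)CCl)C1c1ccc(Cl)cc1`, 57.6%

Among the compounds with values here, in a functional assay on the whole organism for inhibition, with Mus musculus as the target, in the writhing test, with a stated time of 1 h, at a dose of 60 mg/kg by the oral route (on this read-out higher numbers stand for more inhibition at the one dose given (going by the name of the read-out) and lower numbers for less inhibition), compound 2 gives 57.6%, the higher of the two numbers so far; the only neighbour is compound 1 with 51.2%, and the gap between them sits within the scatter. Within the data shown here, the one measured step, a number 6.4 percentage points higher from compound 1 to compound 2 (within the scatter), is therefore no real difference.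

Compound 3 `COc1ccc(C2C(C)C(=O)CC(c3ccc(F)cc3)N2C(=O)CCl)cc1` is not yet measured. It differs from compound 2 in one place: methoxy in place of chloro on an aromatic carbon. Among the measured compounds shown here, the only step that bears on this swap is the hydroxy-to-chloro step from compound 1 to compound 2, which stayed within the scatter, so a change of group on the aromatic carbon in question has so far left the number level. A methoxy in place of chloro on that carbon is expected to behave likewise, giving a step of a number 3.6 percentage points lower from compound 2 to compound 3 (within the scatter) in this assay, none beyond the scatter. Compound 3 is estimated at 54%, between 40% and 68%.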

Compound 3, a percentage reported as inhibition, in the whole organism at one dose (the size of the read-out at that dose, not a potency) in the Mus musculus assay: 51.2%
Compound 3: middle estimate off by 2.8 percentage points, on the high side; the measured number falls inside the stated range.
By their numbers in the Mus musculus assay, from the lowest: compounds 1, 3 and 2 (each within the scatter of the next).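

In the Mus musculus assay the 4-chlorophenyl to 4-methoxyphenyl change gives a number 6.4 percentage points lower from compound 2 to compound 3 (within the scatter) and methyl in place of hydrogen on the oxygen gives no change at the digits printed from compound 1 to compound 3 (within the scatter), so hydroxy, chloro and methoxy on this aromatic carbon now all give numbers within the scatter of one another. In a physicochemical assay for lipophilicity, using the shake flask method (on this read-out higher numbers stand for higher lipophilicity and lower numbers for lower lipophilicity), compound 2 gives 1.72 and compound 3 gives 1.42, which is a number 0.30 log units lower from compound 2 to compound 3 (within the scatter), so this swap separates the two compounds on neither read-out. Nothing at hand explains why the number stays level at this position.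

Open, on these data alone, is whether an amine, a carboxylic acid or a longer chain such as butoxy on this same carbon would move the number beyond the scatter in the Mus musculus assay. Also open, as far as these compounds go, is whether the level picture holds at doses other than the single one given.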